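This account rests on a few compounds, and the source may have more. Where it says the series, first, only, none or still open, it means among the compounds named here.

Of the compounds shown here, three built on one shared core have been measured in a functional assay on NCI-H322M cells (Homo sapiens) for inhibition, read by sulforhodamine B assay, with a stated time of 48 h; a lower number here means a stronger inhibitor of growth, a higher number a weaker inhibitor of growth. Compound 1 `Nc1cc(N)c2nc(-c3ccccc3)c(NCc3ccc(Cl)c(Cl)c3)nc2c1` gives 13500 nM, compound 2 `COc1ccc(CNc2nc3cc(N)cc(N)c3nc2-c2ccccc2)cc1OC` gives 22900 nM, and compound 3 `Nc1cc(N)c2nc(-c3ccccc3)c(NCc3ccc(F)cc3)nc2c1` gives 3470 nM. Compound 3 holds the lowest number of the three: the step of a 3.9-fold lower number from compound 1 to compound 3 (0.59 log units; beyond the scatter) and the step of a 6.6-fold lower number from compound 2 to compound 3 (0.82 log units; beyond the scatter) both lie beyond the scatter, so compound 3 stands as the strongest inhibitor of growth in this small set.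

Compound 4 `COc1ccc(CNc2nc3cc(N)cc(N)c3nc2-c2ccccc2)cc1` has not yet been measured. It differs from compound 3 in one spot: methoxy in place of fluoro on an aromatic carbon. Put more simply, the 4-fluorobenzyl group of compound 3 becomes a 4-methoxybenzyl group.

Two measured steps speak to this change. The step of a 1.7-fold higher number from compound 1 to compound 2 (0.23 log units; within the scatter) exchanged chlorines for methoxy groups and stayed within the scatter. The step of a 6.6-fold lower number from compound 2 to compound 3 (0.82 log units; beyond the scatter), from a 3,4-dimethoxyphenyl to a 4-fluorophenyl, lowered the number clearly, though it altered two groups at once rather than one. Placing a single methoxy where the fluoro sat is therefore expected to raise the number by a modest amount, roughly a 2.6-fold higher number from compound 3 to compound 4 (0.41 log units; beyond the scatter), with nothing in the data to fix the size more closely.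

Compound 4 is estimated at 9000 nM in this assay, with an expected range from 3500 nM to 25000 nM.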

Compound 4, concentration for 50% growth inhibition: 22900 nM
The estimate for compound 4 lay 2.5-fold (0.41 log units) below the measured number, within the range that was stated.
By their numbers in this assay, from the lowest: compound 3; then compounds 1, 2 and 4 (each within the scatter of the next).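

In this assay, the exchange of one fluoro for one methoxy gives a 6.6-fold higher number from compound 3 to compound 4 (0.82 log units; beyond the scatter) and so shows that a single change at this position can produce a step beyond the scatter, whereas the earlier step of the same size, a 6.6-fold lower number from compound 2 to compound 3 (0.82 log units; beyond the scatter), altered two groups at once. Adding the second methoxy makes no visible difference, with no change at the digits printed from compound 2 to compound 4 (within the scatter), and the 3,4-dichlorophenyl group does no differently from the 4-methoxyphenyl group, with a 1.7-fold higher number from compound 1 to compound 4 (0.23 log units; within the scatter) and both steps within the scatter, so compounds 1, 2 and 4 form one level while compound 3, with the 4-fluorobenzyl group, stands apart as the strongest inhibitor of growth in this set. No measurement shown here offers an explanation for this difference.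

From the compounds shown here alone, whether the lower number belongs to fluoro itself stays open, and a plain benzyl group with hydrogen in its place, a 4-chlorobenzyl group or a 4-aminobenzyl group would help to settle that. Also open, going by these compounds, is how a longer chain carrying the 4-fluorophenyl group would compare with compound 3.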